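Swapping Benzyl for Bromobutyl on a Brominated Diaryl Ether

A few compounds are considered here, and "the series" means these few. Any claim that something is new, unique, unknown or untested is made for them only; others in the source may bear on it.

Compound 2 `Brc1ccc(Oc2cc(Br)cc(Br)c2OCc2ccccc2)c(Br)c1` gives 27.9 ug/mL in a functional assay on HL-60 cells (Homo sapiens) for cytotoxicity, read by MTT assay, with a stated time of 24 h (on this read-out higher numbers stand for weaker inhibition and lower numbers for stronger inhibition), and compound 1 `OCCOc1c(Br)cc(Br)cc1Oc1ccc(Br)cc1Br` at 28.2 ug/mL and compound 3 `CN1CCN(CCCCCOc2c(Br)cc(Br)cc2Oc2ccc(Br)cc2Br)CC1` at 48.3 ug/mL both fall within the scatter of that number. Compound 4 `BrCCCCOc1c(Br)cc(Br)cc1Oc1ccc(Br)cc1Br` differs from compound 2 in one place: 3-bromopropyl in place of phenyl on a saturated chain carbon bound to an oxygen on an aromatic ring. Within the data shown here, two measured steps bear on this position. The step of a 1.0-fold lower number from compound 1 to compound 2 (0.00 log units; within the scatter) changes the same saturated chain carbon, and the step of a 1.7-fold higher number from compound 1 to compound 3 (0.23 log units; within the scatter) alters the same chain further along; neither moved the read-out beyond the scatter. Compound 4 is therefore expected to show a 1.1-fold higher number from compound 2 to compound 4 (0.03 log units; within the scatter), with no shift beyond the scatter. The estimate for compound 4 is 30 ug/mL, in a range from 15 ug/mL to 60 ug/mL.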

Compound 4, half-maximal inhibitory concentration: 25.9 ug/mL
Estimate against measurement, compound 4: 1.2-fold (0.06 log units) above; low and high end bracket the measured number.
By their numbers in this assay, from the lowest: compounds 4, 2, 1 and 3 (each within the scatter of the next).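

In this assay, 3-bromopropyl, which has no ring, stands in for phenyl and the read-out stays within the scatter (a 1.1-fold lower number from compound 2 to compound 4 (0.03 log units; within the scatter)), so the ring of the benzyl group is not needed to hold this level. The bromine-bearing chain also stays within the scatter of the hydroxy-bearing chain (a 1.1-fold lower number from compound 1 to compound 4 (0.04 log units; within the scatter)) and the methylpiperazine-bearing chain (a 1.9-fold lower number from compound 3 to compound 4 (0.27 log units; within the scatter)), so all four groups now read alike at this position.

Going by these compounds, whether a carboxylic acid or a nitrile on this chain would move the read-out beyond the scatter stays open. No measurement shown explains why these groups read alike.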